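Swapping Chloro for Bromo on a Soluble Amide

The source may hold more compounds than are shown below. What is called first, only, known or untested is meant among the compounds shown, and "the series" means these compounds.

Measured compounds:
- Compound 1 `Cc1cc(C(=O)Nc2nc(CN)cs2)n(Cc2ccccc2)n1`: in a physicochemical assay for solubility, read by turbidimetry, measured as kinetic solubility, at pH 7.4 (on this read-out lower numbers stand for lower solubility and higher numbers for higher solubility), compound 1 gives 160 ug/mL.
- Compound 2 `CC(C)(C)c1cc(C(=O)Nc2nc(CN)cs2)n(Cc2ccc(Cl)cc2)n1`: in this assay compound 2 gives > 200 ug/mL, which is a limit of the assay rather than a number.

Of the compounds shown here, two have so far been measured in this assay. For compound 2 the reported figure is a limit of the assay and not a number (the limit of > 200 ug/mL in this assay, at which 1 of the 2 values shown sits), so compound 2 stands at the top of what this assay can report, and the two measured values cannot be ranked against each other with any confidence.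

Compound 3 `CC(C)(C)c1cc(C(=O)Nc2nc(CN)cs2)n(Cc2ccc(Br)cc2)n1` has not yet been measured. It differs from compound 2 by bromo in place of chloro on an aromatic carbon, in words bromo in place of chloro on an aromatic carbon. Among the measured compounds shown here, no measured pair in this set shares this change, so the size of the step cannot be read from the data. The expected step of an at least 1.1-fold lower number from compound 2 to compound 3 (0.04 log units; that floor lies within the scatter) in this assay is none beyond the usual scatter, or at most a small decrease. Compound 3 is therefore expected to give about 180 ug/mL, within a range from 90 ug/mL to 200 ug/mL, and it may well be reported only as a limit again.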

Compound 3, solubility: > 200 ug/mL
Compound 3 gave a limit, no number; the forecaster's own chance of this, stated with the estimate: 60%; middle value at least 1.1-fold (0.04 log units) from the limit.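

In this assay compound 3 gives > 200 ug/mL, which is a limit of the assay and not a number. Compound 2 also sits at a limit, so no step can be read between these two compounds: the limit of > 200 ug/mL in this assay, at which 2 of the 3 values shown sit. The compounds shown leave open whether bromo in place of chloro changes the result in this assay at all.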